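Swapping Bromo for Methyl in an Antiproliferative Series

This account rests on a few compounds, and the source may have more. Where it says the series, first, only, none or still open, it means among the compounds named here.

In a functional assay on MCF7 cells (Homo sapiens) for antiproliferative activity, read by MTT assay, with a stated time of 72 h (on this read-out higher numbers stand for weaker inhibition and lower numbers for stronger inhibition), compound 1 `C#CCSc1nc(Sc2nccs2)c(C#N)c(-c2ccc(Br)cc2)n1` gives 11600 nM. Compound 2 `C#CCSc1nc(Sc2nncs2)c(C#N)c(-c2cc(OC)c(OC)c(OC)c2)n1` gives 9820 nM and differs from compound 1 in more than one place. Among the measured compounds shown here, these two numbers lie within the usual scatter of repeated measurements, so compound 1 sits level with the only other measured compound. The next compound, compound 3 `C#CCSc1nc(Sc2nccs2)c(C#N)c(-c2ccc(C)cc2)n1`, carries a single change: methyl in place of bromo on an aromatic carbon, para to a large group (methyl in place of bromo on an aromatic carbon). In other words, 4-bromophenyl becomes 4-methylphenyl. For the measured compounds named here, no measured pair isolates this swap, so the data offer no direct guide, and no step beyond the scatter is expected in this assay, in either direction. The expected result is a 1.1-fold lower number from compound 1 to compound 3 (0.02 log units; within the scatter). For compound 3 the estimated value is 11000 nM, with an expected range from 4500 nM to 27000 nM.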

Compound 3, half-maximal inhibitory concentration: 2200 nM
Compound 3: the middle estimate sits 5.0-fold (0.70 log units) above what was measured; the measured number lies below the stated range.
By their numbers in this assay, from the lowest: compound 3; then compounds 2 and 1 (each within the scatter of the next).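

Bromo and methyl each count one heavy atom, and neither brings a hydrogen-bond donor or acceptor, yet in this assay this single exchange gives a 5.3-fold lower number from compound 1 to compound 3 (0.72 log units; beyond the scatter). This place on the ring, para to a large group, therefore matters to the read-out, which compound 1 and compound 2 could not reveal, as they differ in more than one place and sit level with each other. Nothing measured here on the two groups accounts for the step.

Going by these compounds, whether the lower number is particular to methyl, or would also appear with an ethyl chain, a methoxy group or an amine at this place, stays open. So does whether the same swap would give a similar step in compounds that differ elsewhere on the shared core.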